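A few compounds are considered here, and "the series" means these few. Any claim that something is new, unique, unknown or untested is made for them only; others in the source may bear on it.

Compound 1 `CC(C)c1c(NC(=O)Nc2cnc(-n3nccn3)c(Cl)c2)cnc2ccccc12`: 2420 nM
Compound 2 `CCOC(C)c1c(NC(=O)Nc2cnc(-n3nccn3)c(Cl)c2)cnc2ccccc12`: 1530 nM

Both values come from a functional assay on OCI-Ly3 cells (Homo sapiens) for antiproliferative activity; a higher number here means that more compound is needed for the effect, a lower number that less compound is needed. Going by the values given here, compound 2 stands level with compound 1, the only other compound measured so far. The gap between them is a 1.6-fold lower number from compound 1 to compound 2 (0.20 log units; within the scatter), and it lies within the scatter.

The next compound to be measured is compound 3 `CC(O)c1c(NC(=O)Nc2cnc(-n3nccn3)c(Cl)c2)cnc2ccccc12`, which carries 1-hydroxyethyl where compound 2 carries 1-ethoxyethyl. The change is hydrogen in place of ethyl on an oxygen on a saturated carbon. It is hydrogen in place of ethyl on an oxygen on a saturated carbon.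

Among the compounds with values here, only one measured step bears on this, the one that put ethoxy in place of methyl, and the exchange of these two groups left this assay within the scatter at a 1.6-fold lower number from compound 1 to compound 2 (0.20 log units; within the scatter). Within the data shown here, no measured compound carries a hydroxy group, so this change itself is untested. A step beyond the scatter is therefore not expected, and no firm direction can be given. The expected change is a 1.4-fold higher number from compound 2 to compound 3 (0.16 log units; within the scatter). For compound 3 the estimated value is 2200 nM, with an expected range from 700 nM to 7000 nM.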

Compound 3, half-maximal effective concentration: 730 nM
Estimate against measurement, compound 3: 3.0-fold (0.48 log units) above; the measured number falls inside the stated range.
By their numbers in this assay, from the lowest: compound 3; then compounds 2 and 1 (each within the scatter of the next).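

In this assay, hydrogen in place of ethyl on the oxygen gives a 2.1-fold lower number from compound 2 to compound 3 (0.32 log units; beyond the scatter), and among the steps shown this is the first at this position to lie beyond the scatter, though it is modest. Hydroxy in place of methyl on the same saturated chain carbon gives a 3.3-fold lower number from compound 1 to compound 3 (0.52 log units; beyond the scatter), which leaves compound 3 with the lowest number of the three, whereas ethoxy in place of methyl did not move the value beyond the scatter. No measurement is available that accounts for the difference between the hydroxy compound and the other two.

The compounds shown leave open whether the lower number is specific to the hydroxy group or would also appear with an amine or a methoxy group on this saturated carbon. Going by these compounds alone, they also leave open how a longer chain on the oxygen, or a carboxylic acid in place of the 1-hydroxyethyl group, would read in this assay, since ethyl is the only group on that oxygen other than hydrogen.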